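The source may report more compounds than this note shows. Statements on the series, on what has been measured and on what is new or still open speak of the compounds shown alone.

Measured compounds:
compound 1, `CC(C)CC(=O)Oc1ccc2oc(/C=C/[S+](C)[O-])cc(=O)c2c1`, 2300 nM
compound 2, `COc1ccc2c(=O)cc(/C=C/[S+](C)[O-])oc2c1`, 2200 nM

In a functional assay on A549 cells (Homo sapiens) for cytotoxicity, with a stated time of 48 h (on this read-out higher numbers stand for weaker inhibition and lower numbers for stronger inhibition), compound 1 stands at 2300 nM. Compound 2 stands at 2200 nM. The two numbers lie within the scatter of each other, so neither compound can be set apart from the other. Compound 3, `C[S+]([O-])/C=C/c1cc(=O)c2cc(Br)ccc2o1`, awaits measurement. Its change from compound 1 is bromo in place of (isobutylcarbonyl)oxy on an aromatic carbon: bromo enters on the aromatic carbon where (isobutylcarbonyl)oxy leaves. Within the data shown here, no measured pair shows a change of this kind, and the two values at hand give no direction. Compound 3 is expected to show a step of a 1.1-fold higher number from compound 1 to compound 3 (0.04 log units; within the scatter), nothing beyond the scatter. The estimated value of compound 3 is 2500 nM, within 1000 nM to 6500 nM.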

Compound 3, half-maximal inhibitory concentration: 1100 nM
Estimate against measurement, compound 3: 2.3-fold (0.36 log units) above, within the range that was stated.
By their numbers in this assay, from the lowest: compounds 3, 2 and 1 (each within the scatter of the next, the first and the last beyond it).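

The earlier compounds shown here gave no step at this position, but in this assay bromo in place of (isobutylcarbonyl)oxy on this aromatic carbon gives a 2.1-fold lower number from compound 1 to compound 3 (0.32 log units; beyond the scatter), a modest change. The position therefore does respond to its substituent, and the seven heavy atoms of the (isobutylcarbonyl)oxy group are not needed for activity here. Nothing at hand explains the change. As far as these compounds go, whether the step comes from the presence of bromo or from the loss of (isobutylcarbonyl)oxy stays open. So does what a chloro group, an amine or a carboxylic acid would give on this aromatic carbon.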